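A few compounds are considered here, and "the series" means these few. Any claim that something is new, unique, unknown or untested is made for them only; others in the source may bear on it.

Compound 1 `CCCCC(CCCC)C(O/N=C/C(=O)O)c1ccc(OCc2ccc3ccccc3n2)cc1` gives 10 nM in a functional assay for inhibition of Polyunsaturated fatty acid 5-lipoxygenase (Homo sapiens); a higher number here means a weaker inhibitor, a lower number a stronger inhibitor. Compound 2 `C/C(=N\OC(c1ccc(OCc2ccc3cc(F)ccc3n2)cc1)C1CCCCC1)C(=O)O` gives 20 nM in this assay.

Compound 2 has the higher of the two numbers, but its gap to compound 1 lies within the scatter, so the two are not told apart. Compound 3 `C/C(=N\OC(c1ccc(OCc2nc3ccccc3n2C)cc1)C1CCCCC1)C(=O)O` differs from compound 2 in one place: 1-methyl-1H-benzimidazol-2-yl in place of 6-fluoroquinolin-2-yl on a saturated chain carbon bound to an oxygen on an aromatic ring. Within the data shown here, no measured pair shows this change, so its effect rests on nothing in the data. A modest rise in the number, somewhat beyond the scatter, is expected for compound 3, as a 3.0-fold higher number from compound 2 to compound 3 (0.48 log units; beyond the scatter). Compound 3 is estimated at 60 nM, within 15 nM to 250 nM.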

Compound 3, half-maximal inhibitory concentration: 820 nM
The estimate for compound 3 lay 14-fold (1.14 log units) below the measured number, and the stated range ends below it.
By their numbers in this assay, from the lowest: compounds 1 and 2 (each within the scatter of the next); then compound 3.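

Swapping 6-fluoroquinolin-2-yl for 1-methyl-1H-benzimidazol-2-yl on a saturated chain carbon bound to an oxygen on an aromatic ring gives a 41-fold higher number from compound 2 to compound 3 (1.61 log units; beyond the scatter) in this assay and shows that this position does not tolerate every aromatic group equally. The earlier compounds shown here, which differ in more than one place, offered no single-place comparison and could not show this. No available evidence accounts for the size of this step.

The compounds shown leave open whether the rise comes with the ring change or with the methyl group, as both enter together. Going by these compounds, how a 1H-benzimidazol-2-yl without the methyl, or a benzothiazol-2-yl, would read in this position also remains unknown.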